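Swapping the fused ring on the amide: stability outlook

The compounds below may be only part of what the source reports. "The series", "measured", "known", "first", "only" and "open" are said of these compounds alone.

Compound 3 `O=C(NCc1ccc(S(=O)(=O)N2CCCCC2)cc1)c1cc2ccncc2o1` gives the highest of the three numbers shown in an ADME assay on microsomes from liver (Homo sapiens) for metabolic stability, read by LC-MS, with a stated time of 30 min, tested at 1 uM (a higher number here means that more of the compound is left, a lower number that less of the compound is left), namely 56%. Compound 2 `O=C(NCc1ccc(S(=O)(=O)N2CCCCC2)cc1)c1ccn2cncc2c1` gives 54%, and a number 2 percentage points higher from compound 2 to compound 3 (within the scatter). Compound 1 `O=C(NCc1ccc(S(=O)(=O)N2CCCCC2)cc1)c1cc2cnccc2s1` gives 15%, and a number 41 percentage points higher from compound 1 to compound 3 (beyond the scatter). Compound 4 `O=C(NCc1ccc(S(=O)(=O)N2CCCCC2)cc1)c1ccc2nc[nH]c2c1` differs from compound 3 by a group of 9 heavy atoms (7 carbon, 2 nitrogen; one five-membered aromatic ring with 2 hetero atoms, one six-membered aromatic ring of carbon only) in place of a group of 9 heavy atoms (7 carbon, 1 nitrogen, 1 oxygen; one five-membered aromatic ring with 1 hetero atom, one six-membered aromatic ring with 1 hetero atom), on a carbonyl carbon. Going by the values given here, no measured step covers this exact exchange. The nearest guides are a number 39 percentage points higher from compound 1 to compound 2 (beyond the scatter) and a number 41 percentage points higher from compound 1 to compound 3 (beyond the scatter), which show that exchanging one fused ring pair for another can move the result strongly, while a number 2 percentage points higher from compound 2 to compound 3 (within the scatter) shows that such an exchange can also leave it unchanged. The change to compound 4 is therefore expected to give a number 6 percentage points lower from compound 3 to compound 4 (within the scatter), a step within the scatter. Compound 4 is estimated at 50%, with a range from 30% to 70%.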

Compound 4, percent of the compound remaining: 53%
Estimate against measurement, compound 4: 3 percentage points below, within the range that was stated.
By their numbers in this assay, from the lowest: compound 1; then compounds 4, 2 and 3 (each within the scatter of the next).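

With 1H-benzimidazol-6-yl on the carbonyl carbon, the six-membered aromatic ring is of carbon only, yet this assay gives a number 3 percentage points lower from compound 3 to compound 4 (within the scatter) and a number 1 percentage points lower from compound 2 to compound 4 (within the scatter) so a nitrogen in that ring is not needed to stay level with these two compounds. The large a number 38 percentage points higher from compound 1 to compound 4 (beyond the scatter) leaves compound 1 alone among the four, with three different groups now clear of it. No measured information here gives a cause for this. Going by these compounds, a single phenyl ring on the same carbonyl carbon remains open, as does a sulfur-containing fused group whose six-membered ring is of carbon only.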